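This account rests on a few compounds, and the source may have more. Where it says the series, first, only, none or still open, it means among the compounds named here.

Compound 1 `CN(CCCN1CCCCC1)c1ccc(C(=O)N2CCc3ccc(OS(N)(=O)=O)cc3C2)cc1` was measured in a physicochemical assay for lipophilicity (a lower number here means a more polar compound, a higher number a more lipophilic compound), and gave 1.93. Compound 2 `CCN(Cc1cccc(Br)c1)c1ccc(C(=O)N2CCc3ccc(OS(N)(=O)=O)cc3C2)cc1` sits at the same point in this assay, where compound 2 gives 1.93; the step of no change at the digits printed from compound 1 to compound 2 (within the scatter) shows no movement beyond the scatter. So compound 1 stands level with compound 2 on the numbers available, and nothing among the measured compounds places it higher or lower than any other.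

Compound 3 `CN(C)CCN(CCN(C)C)c1ccc(C(=O)N2CCc3ccc(OS(N)(=O)=O)cc3C2)cc1` has not yet been measured in this assay. It differs from compound 1 as follows: bis(2-(dimethylamino)ethyl)amino in place of methyl(3-(piperidin-1-yl)propyl)amino on an aromatic carbon. For the measured compounds named here, the one measured step, from compound 1 to compound 2, swapped the same side of the molecule for an (3-bromobenzyl)(ethyl)amino group and produced no change within the scatter, so it bears on the present change only loosely. The group that enters, bis(2-(dimethylamino)ethyl)amino, has no ring and one more hydrogen-bond acceptor than the methyl(3-(piperidin-1-yl)propyl)amino group that leaves, and the account therefore expects a modest downward step a number 0.43 log units lower from compound 1 to compound 3 (beyond the scatter) for compound 3 in this assay. Compound 3 is estimated at 1.5, with a range from 0.9 to 2.1.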

Compound 3, partition coefficient: 1.93
Compound 3: middle estimate off by 0.43 log units, on the low side; low and high end bracket the measured number.
By their numbers in this assay, from the lowest: compounds 1, 2 and 3 (each within the scatter of the next).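

In this assay the exchange of methyl(3-(piperidin-1-yl)propyl)amino for bis(2-(dimethylamino)ethyl)amino gives no change at the digits printed from compound 1 to compound 3 (within the scatter) and so shows that, at this aromatic carbon, removing the six-membered non-aromatic ring and having 3 hydrogen-bond acceptors in place of 2 brings no movement in the read-out. The exchange of (3-bromobenzyl)(ethyl)amino for the same group gives no change at the digits printed from compound 2 to compound 3 (within the scatter) and extends the earlier single match to all three compounds, whose very different groups para to a large group read alike. No measurement at hand explains why these groups give matching numbers.

What the compounds leave open is whether this level holds for other kinds of group at the same place, such as a carboxylic acid, a primary amine or a longer chain ending in a hydroxyl group. They also leave open whether any replacement of the amino group on this aromatic carbon can move the read-out beyond the scatter, since all three compounds shown carry a tertiary amine there.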